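Bromo-to-chloro exchange on two arms of one series

The compounds below may be only part of what the source reports. "The series", "measured", "known", "first", "only" and "open" are said of these compounds alone.

Measured compounds:
compound 1, `Clc1cccc(CSc2nnc(-c3ccncc3)n2-c2ccccc2)c1`, gives 11200 nM in a functional assay on HepG2 cells (Homo sapiens) for inhibition, read by MTT assay, with a stated time of 48 h; on this read-out higher numbers stand for weaker inhibition and lower numbers for stronger inhibition.
compound 2, `Brc1cccc(CSc2nnc(-c3ccncc3)n2-c2ccccc2)c1`, gives 7040 nM in this assay.
compound 3, `O=C(CSc1nnc(-c2ccncc2)n1-c1ccccc1)N/N=C/c1ccc(Br)cc1`, gives 5990 nM in this assay.

Compound 1 and compound 2 share one core and differ only at a halogen. The change between them is chloro in place of bromo on an aromatic carbon, and it reads as a 1.6-fold higher number from compound 2 to compound 1 (0.20 log units; within the scatter).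

Compound 3 carries a different core; the difference between the core of compound 2 and the core of compound 3 is not broken down here. In this assay compound 3 sits within the scatter of both compound 2 and compound 1, so the three measured values do not separate from one another.

The unmeasured compound 4, `O=C(CSc1nnc(-c2ccncc2)n1-c1ccccc1)N/N=C/c1ccc(Cl)cc1`, relates to compound 3 as chloro in place of bromo on an aromatic carbon. This is the same kind of change as that from compound 2 to compound 1, not the same: there the halogen sits meta to a large group on the ring, here it sits para to a large group. For the measured compounds named here, with only one measured instance, and that one within the scatter, the expectation for compound 4 is a small step, estimated as a 1.3-fold higher number from compound 3 to compound 4 (0.13 log units; within the scatter), resting on the step of a 1.6-fold higher number from compound 2 to compound 1 (0.20 log units; within the scatter) seen on the other arm of the series. Compound 4 is therefore expected to give about 8000 nM in this assay, with a likely range from 4000 nM to 16000 nM.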

Compound 4, half-maximal inhibitory concentration: 11000 nM
The estimate for compound 4 lay 1.4-fold (0.14 log units) below the measured number, within the range that was stated.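

In this assay, chloro in place of bromo on an aromatic carbon gives a 1.8-fold higher number from compound 3 to compound 4 (0.26 log units; within the scatter), so on this second core the exchange again stays within the scatter. Set beside the earlier step on the other core, the new step does not differ from it, and the exchange carries across the two cores without a detectable dependence on the core: the same change on two cores in this assay, a 1.6-fold higher number (0.20 log units; within the scatter) from compound 2 to compound 1 and a 1.8-fold higher number (0.26 log units; within the scatter) from compound 3 to compound 4, 1.2-fold (0.06 log units) apart, within the scatter of two such steps. This agreement is limited, as neither step separates chloro from bromo on its own, so the two steps point the same way but do not establish a real difference between the halogens, and two cores are too few to support a rule for the whole series.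

What stays open is how other groups would read at the same place on the ring, such as fluoro, methyl, methoxy, trifluoromethyl, an amine or a carboxylic acid, since the compounds shown carry only chloro and bromo and so span too narrow a range to show whether this position matters for the read-out at all. Also open, from the compounds shown here alone, is whether the exchange behaves the same way on any core beyond these two.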